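A few compounds are considered here, and "the series" means these few. Any claim that something is new, unique, unknown or untested is made for them only; others in the source may bear on it.

Compound 3 `Cc1cc(NC(=O)Nc2ccc(C(N)=O)cc2)c2ccccc2n1` carries the lowest number of the three in a physicochemical assay for solubility, at pH 7.4 (on this read-out lower numbers stand for lower solubility and higher numbers for higher solubility), giving 900 nM. Compound 1 `Cc1cc(NC(=O)Nc2ccc(C(=O)O)cc2)c2ccccc2n1` gives 9300 nM and compound 2 `COC(=O)c1ccc(NC(=O)Nc2cc(C)nc3ccccc23)cc1` gives 1200 nM. The gap a 10-fold lower number from compound 1 to compound 3 (1.01 log units; beyond the scatter) is beyond the scatter, whereas a 1.3-fold lower number from compound 2 to compound 3 (0.12 log units; within the scatter) is within it, so compound 3 and compound 2 cannot be separated. Compound 4 `Cc1cc(NC(=O)Nc2ccc(C(F)(F)F)cc2)c2ccccc2n1` differs from compound 3 by trifluoromethyl in place of carbamoyl on an aromatic carbon. For the measured compounds named here, none of the measured steps touches this change; a 7.8-fold lower number from compound 1 to compound 2 (0.89 log units; beyond the scatter) and a 10-fold lower number from compound 1 to compound 3 (1.01 log units; beyond the scatter) alter only the group on the carbonyl carbon, so they offer no direct guide. A modest step downward is expected, a 3.0-fold lower number from compound 3 to compound 4 (0.48 log units; beyond the scatter), with wide uncertainty. Compound 4 is estimated at 300 nM, within 60 nM to 1500 nM.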

Compound 4, solubility: 100 nM
Estimate against measurement, compound 4: 3.0-fold (0.48 log units) above; low and high end bracket the measured number.
By their numbers in this assay, from the lowest: compound 4; then compounds 3 and 2 (each within the scatter of the next); then compound 1.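

In this assay, trifluoromethyl on this aromatic carbon gives the lowest number of the four compounds, with a 9.0-fold lower number from compound 3 to compound 4 (0.95 log units; beyond the scatter) and a 12-fold lower number from compound 2 to compound 4 (1.08 log units; beyond the scatter) and a 93-fold lower number from compound 1 to compound 4 (1.97 log units; beyond the scatter) as its steps. Compounds 1, 2 and 3 all keep a carbonyl carbon at this position, whereas compound 4 has none and its trifluoromethyl has no hydrogen-bond donor or acceptor, and it separates from all three beyond the scatter. No measurement here explains the drop. Where a nitrile, a methyl group or a chlorine atom at this carbon would fall remains open.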